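The source may report more compounds than this note shows. Statements on the series, on what has been measured and on what is new or still open speak of the compounds shown alone.

Measured so far:
compound 1 `CSCc1cc(C(C)=O)c(O)cc1OCCCCCCC#N`: 97%
compound 2 `C=CCc1cc(C(C)=O)c(O)cc1OCCCCCCC#N`: 97%

Going by the values given here, in an assay on isolated protein for inhibition of leukotriene B4 receptor 1 (Homo sapiens), tested at 10 uM (a lower number here means less inhibition, a higher number more inhibition at the concentration tested (going by the name of the read-out)), compound 2 stands level with compound 1 at the digits reported; the one measured step, no change at the digits printed from compound 1 to compound 2 (within the scatter), lies within the scatter. Compound 3 `C=CCc1cc(C(C)=O)c(O)cc1OCCCCCC` differs from compound 2 by hydrogen in place of cyano on a saturated chain carbon, six bonds along the chain from an oxygen on an aromatic ring. Among the compounds with values here, no measured step touches this change, and the flat step already seen concerned another part of the molecule, so it gives no direction. The expected step is therefore a number 7 percentage points lower from compound 2 to compound 3 (within the scatter), nothing beyond the scatter. Compound 3 is accordingly estimated at 90%, with a range from 70% to 99%.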

Compound 3, a percentage reported as inhibition, at one concentration (the size of the read-out at that concentration, not a potency): 50%
For compound 3 the middle estimate is 40 percentage points above the measured one, and the stated range ends above it.
By their numbers in this assay, from the lowest: compound 3; then compounds 1 and 2 (each within the scatter of the next).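

Hydrogen in place of cyano on the saturated chain carbon, six bonds along the chain from an oxygen on an aromatic ring, gives a number 47 percentage points lower from compound 2 to compound 3 (beyond the scatter) in this assay. The end of this chain is therefore a place where the read-out responds strongly, unlike the site that differs between compound 1 and compound 2. Nothing available explains the loss.

The compounds shown leave open whether the nitrile itself is needed, or whether a carboxylic acid or a primary amide at the chain end would hold inhibition at the level of compound 2. As far as these compounds go, how a longer chain bearing the nitrile would behave also remains open.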